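Replacing 3-methoxyphenyl with naphthalen-2-yl

A few compounds are considered here, and "the series" means these few. Any claim that something is new, unique, unknown or untested is made for them only; others in the source may bear on it.

Of the compounds shown here, two sharing one core have been measured in a functional assay on Raji cells (Homo sapiens) for inhibition, read by MTT assay, with a stated time of 96 h; a lower number here means a stronger inhibitor, a higher number a weaker inhibitor. Compound 1 `CCC(C)Oc1cc(NC(=O)/C(C#N)=C(/C)O)c(F)cc1-c1cccc2ccccc12`, which carries naphthalen-1-yl, gives 215 nM. Compound 2 `CCC(C)Oc1cc(NC(=O)/C(C#N)=C(/C)O)c(F)cc1-c1cccc(OC)c1`, which carries 3-methoxyphenyl, gives 610 nM, the higher of the two numbers, which makes it the weaker inhibitor of the pair. Compound 3 `CCC(C)Oc1cc(NC(=O)/C(C#N)=C(/C)O)c(F)cc1-c1ccc2ccccc2c1` has naphthalen-2-yl in place of 3-methoxyphenyl on an aromatic carbon, ortho to a sec-butoxy group: naphthalen-2-yl in place of 3-methoxyphenyl on an aromatic carbon. Among the compounds with values here, only one measured step bears on this change: a 2.8-fold higher number from compound 1 to compound 2 (0.45 log units; beyond the scatter), modest in size and beyond the scatter. Read in reverse, it suggests that exchanging 3-methoxyphenyl for a naphthyl group could lower the number. However, compound 3 carries naphthalen-2-yl rather than the naphthalen-1-yl of compound 1, and no measurement yet compares those two groups, so the earlier step is only a rough guide. A step of similar size in this assay, toward a lower number, is therefore expected, estimated as a 2.1-fold lower number from compound 2 to compound 3 (0.32 log units; beyond the scatter). For compound 3 the expected value is 290 nM, with an estimated range of 125 nM to 650 nM.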

Compound 3, half-maximal inhibitory concentration: 18.8 nM
The estimate for compound 3 lay 15-fold (1.19 log units) above the measured number, outside the stated range (below it).
By their numbers in this assay, from the lowest: compound 3; then compound 1; then compound 2.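

In this assay, the place ortho to a sec-butoxy group turns out to be far more sensitive than the earlier pair showed: naphthalen-2-yl in place of 3-methoxyphenyl gives a 32-fold lower number from compound 2 to compound 3 (1.51 log units; beyond the scatter) and makes compound 3 the strongest inhibitor of the three. The two naphthyl groups are also not interchangeable, since naphthalen-2-yl in place of naphthalen-1-yl gives an 11-fold lower number from compound 1 to compound 3 (1.06 log units; beyond the scatter) even though the entering and leaving groups have the same atoms, so the point of attachment alone carries a large step, one greater than a 2.8-fold higher number from compound 1 to compound 2 (0.45 log units; beyond the scatter) for the earlier change. No evidence is available here to explain why these steps are so large.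

On these data alone, it remains open whether a phenyl ring carrying an amine or a carboxylic acid at this same place would keep a number as low as that of compound 3, or would fall closer to compound 2. All three compounds also share the sec-butoxy and fluoro groups, so the compounds shown do not tell whether the gain from naphthalen-2-yl would hold with a longer chain in place of the sec-butoxy group.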